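The source may report more compounds than this note shows. Statements on the series, on what has been measured and on what is new or still open speak of the compounds shown alone.

Measured compounds and their values in an ADME assay on Vero cells (Chlorocebus sabaeus) for cytotoxicity, read by MTT assay, with a stated time of 72 h; a lower number here means that less compound is tolerated, a higher number that more compound is tolerated:

compound 1, `COC(=O)c1cc(-c2cccc(NC(=O)c3ccc(/C=C/C(=O)c4ccc(F)cc4F)cc3)c2)on1`: > 40 ug/mL
compound 2, `COC(=O)c1cc(-c2ccc(NC(=O)c3ccc(/C=C/C(=O)c4ccc(Cl)cc4)cc3)cc2)on1`: > 80 ug/mL
compound 3, `COC(=O)c1cc(-c2cccc(NC(=O)/C=C/c3ccc(Cl)cc3)c2)on1`: "not determined" (no result reported)

In this assay compound 1 gives > 40 ug/mL, which is a limit of the assay and not a number. Compound 2 likewise reaches only a limit, > 80 ug/mL, in this assay. For compound 3 no result was reported in this assay. Compound 1 therefore stands among values of which none is a single number: one further entry is a limit, and one is empty. Among the compounds with values here, the evidence on this series amounts to the limits themselves, the limit of > 40 ug/mL in this assay, at which 1 of the 3 values shown sits, and (the limit of > 80 ug/mL in this assay, at which 1 of the 3 values shown sits), and no step between measured compounds that differ in one place can be drawn from them.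

The step to be followed leads from compound 1 to compound 4, `COC(=O)c1cc(-c2cccc(NC(=O)c3ccc(/C=C/C(=O)c4cccc(F)c4)cc3)c2)on1`. The change is 3-fluorophenyl in place of 2,4-difluorophenyl on a carbonyl carbon. Within the data shown here, no step among the measured compounds shows what this exchange does in this assay. Given that compound 1 sits at its limit of > 40 ug/mL, compound 4 is expected to show no change beyond the scatter, a step that the limit leaves unreadable from compound 1 to compound 4, and most likely to reach a limit as well. The estimate for compound 4 in this assay is 50 ug/mL, within a range from 25 ug/mL to 100 ug/mL.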

Compound 4, half-maximal cytotoxic concentration: > 40 ug/mL
Compound 4: a limit, no number; the forecaster's own chance of this, stated with the estimate: 70%; the middle value is on the limit's open side.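

In this assay compound 4 gives > 40 ug/mL, which is a limit of the assay and not a number. Compound 1 also reaches only a limit, so no step can be read between compound 1 and compound 4. The compounds shown leave open what 3-fluorophenyl in place of 2,4-difluorophenyl on a carbonyl carbon does in this assay.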